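This account rests on a few compounds, and the source may have more. Where it says the series, first, only, none or still open, it means among the compounds named here.

Measured so far:
compound 1 `COc1cccc(S(=O)(=O)/C=C/c2cccnc2)c1` — 100%
compound 2 `COc1cccc(S(=O)(=O)/C=C/c2ccncc2)c1` — 84.3%

Within the data shown here, in an ADME assay on BV-2 cells (Mus musculus) for cytotoxicity, with a stated time of 24 h, tested at 10 uM (a lower number here means a stronger effect, a higher number a weaker effect of the compound at the concentration tested), compound 2 stands lowest of the two numbers, with compound 1 nearest; the only measured step is a number 15.7 percentage points lower from compound 1 to compound 2 (beyond the scatter). Compound 3 `COc1cccc(S(=O)(=O)/C=C/c2cncnc2)c1` differs from compound 2 by pyrimidin-5-yl in place of pyridin-4-yl on a double-bonded chain carbon bound to a double-bonded chain carbon. Among the measured compounds shown here, no measured step involves a pyrimidin-5-yl ring, so that one step offers only loose guidance, and a further change of modest size or none beyond the scatter seems most likely. Compound 3 is therefore estimated at 88%, within 68% to 105%. This estimate means an expected a number 3.7 percentage points higher from compound 2 to compound 3 (within the scatter).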

Compound 3, a percentage reported as activity, at one concentration (the size of the read-out at that concentration, not a potency): 100%
Estimate against measurement, compound 3: 12 percentage points below; low and high end bracket the measured number.
By their numbers in this assay, from the lowest: compound 2; then compounds 1 and 3 (each within the scatter of the next).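

Pyrimidin-5-yl in place of pyridin-4-yl gives a number 15.7 percentage points higher from compound 2 to compound 3 (beyond the scatter) in this assay and, in place of pyridin-3-yl, it gives no change at the digits printed from compound 1 to compound 3 (within the scatter) at the same place on the chain. Among these three rings, then, only pyridin-4-yl lowers the number, and the ring with 2 nitrogens does not lower it further. No available evidence explains this difference between the rings.

As far as these compounds go, it remains open whether a plain phenyl ring would behave like pyridin-4-yl or like the other two rings. From the compounds shown here alone, the effect of adding an amine to the ring also remains open.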